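The compounds below may be only part of what the source reports. "The series", "measured", "known", "first", "only" and "open" are said of these compounds alone.

Measured so far in a functional assay on HEK293 cells for antagonist activity at transient receptor potential cation channel subfamily V member 1 (Homo sapiens), read by calcium flux; on this read-out lower numbers stand for stronger inhibition and higher numbers for weaker inhibition:

Compound 1 `FC(F)(F)c1ccc(Nc2ncnc3sc(Nc4c(Cl)cccc4Cl)nc23)cc1`: 12 nM
Compound 2 `NS(=O)(=O)c1ccc(Nc2ncnc3sc(Nc4c(Cl)cccc4Cl)nc23)cc1`: > 5000 nM

Within the data shown here, compound 1 is the only compound of the pair with an actual number in this assay; for compound 2 the assay reports only a limit, (the limit of > 5000 nM in this assay, at which 1 of the 2 values shown sits), and no number. Among the measured compounds shown here, the one measured step, an at least 410-fold higher number from compound 1 to compound 2 (2.61 log units; beyond the scatter), is large and lies beyond the scatter, but it changes the group on the (4-(trifluoromethyl)phenyl)amino ring, and nothing in the measured pair touches the fused core.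

Compound 3 `CCN(CC)c1nc(Nc2ccc(C(F)(F)F)cc2)c2nc(Nc3c(Cl)cccc3Cl)sc2n1` differs from compound 1 in just such a way: diethylamino in place of hydrogen on an aromatic carbon. For the measured compounds named here, no measured step bears on this position, so the expectation rests on compound 1 alone, whose value of 12 nM serves as the anchor, with a broad margin for the unknown effect of a fresh substituent on the core. Compound 3 is expected to give about 25 nM in this assay, with a range from 6 nM to 120 nM. The estimated step, a 2.1-fold higher number from compound 1 to compound 3 (0.32 log units; beyond the scatter), is expected to be small, in the direction of a somewhat higher number.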

Compound 3, half-maximal inhibitory concentration: 48 nM
Beside the measured number, compound 3's estimate is 1.9-fold (0.28 log units) below it; low and high end bracket the measured number.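

In this assay, diethylamino in place of hydrogen on the aromatic carbon between two ring nitrogen atoms gives a 4.0-fold higher number from compound 1 to compound 3 (0.60 log units; beyond the scatter), the first view of what a change to the shared core does, since the earlier pair spoke only to the group on the (4-(trifluoromethyl)phenyl)amino ring. The step is modest but lies beyond the scatter, so this position tolerates a branched, ring-free amine with some cost, and compound 3 still gives a measured 48 nM in this assay rather than a limit. Nothing given here explains the size or direction of this step.

With diethylamino as the only substituent shown at this position, it remains open whether a smaller group such as a methyl or a simple amino group would stay closer to compound 1, and whether a cyclic amine such as morpholine or piperidine would behave like diethylamino. Going by these compounds, it also remains open whether the cost seen with compound 3 would hold alongside a group other than trifluoromethyl on the aniline ring.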